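The compounds below may be only part of what the source reports. "The series", "measured", "known", "first", "only" and "open" are said of these compounds alone.

Compound 1 `O=C(CCSc1nnc(-c2ccncc2)s1)Nc1ccccc1`. In an ADME assay on HepG2 cells (Homo sapiens) for cytotoxicity, with a stated time of 3 days (on this read-out lower numbers stand for higher toxicity in this test and higher numbers for lower toxicity in this test), compound 1 gives > 50000 nM, which is a limit of the assay and not a number.
Compound 2 `CC(CSc1nnc(-c2ccncc2)s1)C(=O)Nc1ccccc1`. In this assay compound 2 gives > 50000 nM, again a limit.
Compound 3 `O=C(CSc1nnc(-c2ccncc2)s1)NCc1ccccc1`. In this assay compound 3 gives 17700 nM.

Compound 1 therefore stands only at a limit, and the limit of > 50000 nM in this assay, at which 2 of the 3 values shown sit, marks where it sits. Going by the values given here, the single step that touches it, a step that the two limits leave unreadable from compound 1 to compound 2, cannot be read for that reason. Among the compounds with values here, compound 3 is the only one that gives a number, and no step between it and compound 1 is available. Compound 4 `O=C(CCSc1nnc(-c2ccncc2)s1)NCc1ccc(Cl)cc1` carries 4-chlorobenzyl in place of phenyl on an amide-type nitrogen. Within the data shown here, no measured step bears on this change, so the expected step of an at least 1.6-fold lower number from compound 1 to compound 4 (0.22 log units; that floor lies within the scatter) rests on little and is held open. Compound 4 is expected to give 30000 nM, in the range 10000 nM to 90000 nM.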

Compound 4, half-maximal cytotoxic concentration: 15600 nM
The estimate for compound 4 lay 1.9-fold (0.28 log units) above the measured number; the range from low to high includes it.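

In this assay, the amide-type nitrogen gives the first readable step around compound 1: 4-chlorobenzyl in place of phenyl yields an at least 3.2-fold lower number from compound 1 to compound 4 (0.50 log units; beyond the scatter). The group on this nitrogen therefore matters in this read-out, and the change brings the result from a limit to a number. The size remains only a floor because compound 1 stands at a limit: the limit of > 50000 nM in this assay, at which 2 of the 4 values shown sit.

Whether the step belongs to the chlorine or to the benzyl remains open, as the plain benzyl on this chain is not among the compounds shown. As far as these compounds go, how a 4-methoxybenzyl or a longer phenethyl chain on this nitrogen would read also remains open.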